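The source may hold more compounds than are shown below. What is called first, only, known or untested is meant among the compounds shown, and "the series" means these compounds.

Compound 2 `Cc1cc(-c2c(C)nn(C)c2C)ccc1-c1nnc(N(C)Cc2ccc3ncc(C4CCN(C)CC4)n3c2)o1` carries a 1-methylpiperidin-4-yl group on the shared core. Among the measured compounds shown here, in an assay on COS-7 cells for inhibition of tyrosine-protein kinase receptor UFO (Homo sapiens), read by ELISA, with a stated time of 1 h (a higher number here means a weaker inhibitor, a lower number a stronger inhibitor), compound 2 gives 1260 nM, the higher of the two numbers measured so far. For the measured compounds named here, its only neighbour is compound 1 `Cc1cc(-c2c(C)nn(C)c2C)ccc1-c1nnc(N(C)Cc2ccc3ncc(-c4ccccc4)n3c2)o1`, which has phenyl at the same place and in this assay gives 200 nM. Going by the values given here, the single step on record, a 6.3-fold higher number from compound 1 to compound 2 (0.80 log units; beyond the scatter), therefore describes what happened when phenyl gave way to the saturated ring.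

Compound 3 `Cc1cc(-c2c(C)nn(C)c2C)ccc1-c1nnc(N(C)Cc2ccc3ncc(-c4cnn(CCN(C)C)c4)n3c2)o1` alters compound 2 in one place: 1-(2-(dimethylamino)ethyl)-1H-pyrazol-4-yl in place of 1-methylpiperidin-4-yl on an aromatic carbon. The incoming group is again an aromatic ring on the same aromatic carbon, as phenyl was in compound 1, while its 2-(dimethylamino)ethyl chain brings in a nitrogen outside the ring. Among the compounds with values here, only the step from compound 1 to compound 2 bears on this change, and it suggests that returning to an aromatic ring would bring the number back toward that of compound 1, though not fully, since the new ring is not phenyl. Compound 3 is therefore expected to give 450 nM, within 150 nM to 1400 nM, an expected step of a 2.8-fold lower number from compound 2 to compound 3 (0.45 log units; beyond the scatter).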

Compound 3, half-maximal inhibitory concentration in the tyrosine-protein kinase receptor UFO assay: 126 nM
The estimate for compound 3 lay 3.6-fold (0.55 log units) above the measured number, outside the stated range (below it).
By their numbers in the tyrosine-protein kinase receptor UFO assay, from the lowest: compounds 3 and 1 (each within the scatter of the next); then compound 2.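

In the tyrosine-protein kinase receptor UFO assay, the result shows that the weak number of compound 2 belongs to the 1-methylpiperidin-4-yl group and not to the position as a whole, which the step alone makes plain: a 10-fold lower number from compound 2 to compound 3 (1.00 log units; beyond the scatter). It also shows that this aromatic carbon accepts a larger group with a 2-(dimethylamino)ethyl chain at no measurable cost relative to phenyl, with a 1.6-fold lower number from compound 1 to compound 3 (0.20 log units; within the scatter), so compound 3 and compound 1 cannot be told apart here. In a physicochemical assay for lipophilicity, at pH 7.4 (a lower number here means a more polar compound, a higher number a more lipophilic compound), compound 2 gives 2.5 and compound 3 gives 3.5. The better binder of the pair is also the more lipophilic one in the physicochemical assay, so the change from the saturated ring to the new aromatic group moves both read-outs at once: the measured distribution coefficient of compound 2, 2.5, and of compound 3, 3.5, a number 1.00 log units higher (beyond the scatter).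

The five-membered aromatic ring and its 2-(dimethylamino)ethyl chain enter together, so the compounds shown leave open which of them accounts for the step, a question that a plain 1-methyl-1H-pyrazol-4-yl group or a longer amine chain could help to settle. A single pair also cannot tell whether the two read-outs are linked or merely moved together in this one change.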